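This account rests on a few compounds, and the source may have more. Where it says the series, first, only, none or still open, it means among the compounds named here.

Measured compounds:
- Compound 1 `COc1ccc(F)cc1CNCCCNc1ccnc2cc(Cc3ccc(C#N)cc3)ccc12`: 9.47
- Compound 2 `CC(C)(C)c1ccc(Oc2ccc3c(NCCCNCc4ccco4)ccnc3c2)cc1`: 9.28
- Compound 3 `Cc1cc(C)cc(Cc2ccc3c(NCCCNCc4ccco4)ccnc3c2)c1`: 9.47

These three compounds share one core and were each examined in a physicochemical assay for acid dissociation. In this assay compound 1 gives 9.47. Compound 3 gives 9.47, the same number at the digits shown. Compound 2 gives 9.28, which differs from the number of compound 1 by an amount that falls within the usual scatter of repeated measurements, so the three compounds cannot be told apart on this read-out.

Compound 4 `COc1cccc(Oc2ccc3c(NCCCNCc4cc(F)ccc4OC)ccnc3c2)c1` has not yet been measured. Compared with compound 1 it carries one change: 3-methoxyphenoxy in place of 4-cyanobenzyl on an aromatic carbon. The group that is exchanged sits on the core, meta to a fused ring and para to a fused ring, at some distance from the chain that links the two ends of the molecule. Among the measured compounds, no pair differs in only one place, so no single step in this assay can be read off directly. Given that compounds 1, 2 and 3, which differ from one another at this same region of the core, all sit within the scatter of each other, the expected step from compound 1 to compound 4 is a number 0.07 log units lower from compound 1 to compound 4 (within the scatter), which amounts to no change beyond the scatter. The estimate for compound 4 in this assay is therefore 9.4, with a range from 9 to 9.8.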

Compound 4, acid dissociation constant: 9.28
The estimate for compound 4 lay 0.12 log units above the measured number, and the stated range covers the measured number.
By their numbers in this assay, from the lowest: compounds 2, 4, 1 and 3 (each within the scatter of the next).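

In this assay, among the compounds shown here, compounds 1 and 4 give the first pair that differs in one place, and the step reads a number 0.19 log units lower from compound 1 to compound 4 (within the scatter) when 3-methoxyphenoxy takes the place of 4-cyanobenzyl on an aromatic carbon of the core. The two groups have the same count of heavy atoms and each holds one six-membered aromatic ring of carbon only, but the leaving group brings a nitrile and the entering group brings two oxygens, and this exchange at this place gives no step beyond the scatter. No measurement shown here accounts for this result.

Between the other compounds no single step can be read, as they differ in more than one place, so this one step is all that is known about the position. Still open, as far as these compounds go, is whether a group of a quite different kind on this aromatic carbon, such as an amine or a carboxylic acid, or a longer chain between the two ends of the molecule, would give a step beyond the scatter in this assay for the compounds built on this core.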